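Trimming one methoxy group from the aryl ring of compound 2

A few compounds are considered here, and "the series" means these few. Any claim that something is new, unique, unknown or untested is made for them only; others in the source may bear on it.

Measured compounds:
compound 1 `COc1ccc(-c2cc(/C=C/C(=O)c3ccc(N)cc3)[nH]n2)cc1`, 1420 nM
compound 2 `COc1cc(-c2cc(/C=C/C(=O)c3ccc(N)cc3)[nH]n2)cc(OC)c1OC`, 720 nM
compound 3 `COc1cc(-c2cc(/C=C/C(=O)c3ccc(F)c(F)c3)[nH]n2)cc(OC)c1OC`, 3310 nM

In a functional assay on K562 cells (Homo sapiens) for inhibition, read by sulforhodamine B assay, with a stated time of 48 h (a lower number here means a stronger inhibitor of growth, a higher number a weaker inhibitor of growth), compound 2 gives the lowest of the three numbers, with compound 1 at 1420 nM within the scatter of it and compound 3 at 3310 nM beyond it. Within the data shown here, the one measured step, a 4.6-fold higher number from compound 2 to compound 3 (0.66 log units; beyond the scatter), concerns the aryl group on the carbonyl carbon and leaves the methoxy-bearing ring untouched.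

Compound 4 `COc1ccc(-c2cc(/C=C/C(=O)c3ccc(N)cc3)[nH]n2)cc1OC` differs from compound 2 at that ring: hydrogen in place of methoxy on an aromatic carbon. Among the measured compounds shown here, no measured step touches this position directly. What the data show is that compound 1, with a single methoxy group on the ring, and compound 2, with three, lie within the scatter of each other in this assay, so the count of methoxy groups on this ring has not so far moved the number beyond the scatter. Compound 4, with two methoxy groups, sits between them in structure, and the expected step of a 1.4-fold higher number from compound 2 to compound 4 (0.14 log units; within the scatter) is therefore a small one, not beyond the scatter, in the direction of compound 1. Compound 4 is accordingly estimated at 1000 nM in this assay, with a range from 400 nM to 2500 nM.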

Compound 4, concentration for 50% growth inhibition: 2030 nM
The estimate for compound 4 lay 2.0-fold (0.31 log units) below the measured number, within the range that was stated.
By their numbers in this assay, from the lowest: compounds 2, 1, 4 and 3 (each within the scatter of the next, the first and the last beyond it).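

In this assay, the methoxy group that compound 2 carries ortho to a methoxy group and meta to a large group proves to matter, since hydrogen in its place gives a 2.8-fold higher number from compound 2 to compound 4 (0.45 log units; beyond the scatter) and so separates the two compounds. The same kind of change does not separate compounds on the ring of compound 1, where methoxy in place of hydrogen gives a 1.4-fold higher number from compound 1 to compound 4 (0.16 log units; within the scatter) and leaves the two within the scatter of each other, so among these compounds the effect of one methoxy group depends on which ring it is set into and the count of methoxy groups alone does not settle the number. Nothing available here accounts for this difference between the two steps.

The compounds shown leave open whether an ethoxy group, a hydroxyl group or a fluorine atom at this place would stay as close to compound 2 as methoxy does or fall with hydrogen. They also leave open whether hydrogen in place of methoxy would give a step of similar size with 3,4-difluorophenyl on the carbonyl carbon, as in compound 3, for the step is read here only with 4-aminophenyl there.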